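The compounds below may be only part of what the source reports. "The series", "measured", "known", "first", "only" and "open" are said of these compounds alone.

Measured so far in an ADME assay on microsomes from liver (Homo sapiens) for metabolic stability; on this read-out lower numbers stand for slow clearance and higher numbers for fast clearance:
compound 1 `Cc1cc(C)c(-c2nc3ccccc3[nH]2)cc1NC(=O)c1ccc(OCc2ccccn2)cc1` gives 30 mL.min-1.g-1
compound 2 `Cc1csc(-c2cc(NC(=O)c3ccc(OCc4ccccn4)cc3)c(C)cc2C)n1` gives 513 mL.min-1.g-1
compound 3 `Cc1cc(C)c(-c2cccc(N)n2)cc1NC(=O)c1ccc(OCc2ccccn2)cc1` gives 88 mL.min-1.g-1

Compound 3 stands second highest of the three numbers in this assay. Its nearest neighbour is compound 1, with the step of a 2.9-fold higher number from compound 1 to compound 3 (0.47 log units; beyond the scatter); furthest is compound 2, with the step of a 5.8-fold lower number from compound 2 to compound 3 (0.77 log units; beyond the scatter). The whole spread of the series lies in the group on the shared core, as the step of a 17-fold higher number from compound 1 to compound 2 (1.23 log units; beyond the scatter) shows.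

Compound 4 `Cc1cc(C)c(-c2ccc(N)nn2)cc1NC(=O)c1ccc(OCc2ccccn2)cc1` differs from compound 3 by one change: 6-aminopyridazin-3-yl in place of 6-aminopyridin-2-yl on an aromatic carbon. The measured steps all bear on the same position, but each exchanges the entire group for another of different ring size or ring count. The present change keeps the amino group and the six-membered ring, and the counted difference is one ring carbon against one ring nitrogen, with one more hydrogen-bond acceptor. Within the data shown here, it is the smallest change so far, so a step smaller than any measured is expected, in this assay most likely downward, and it may not clear the scatter.

Compound 4 is expected to give 60 mL.min-1.g-1 in this assay, within 25 mL.min-1.g-1 to 150 mL.min-1.g-1, which would be a step of a 1.5-fold lower number from compound 3 to compound 4 (0.17 log units; within the scatter).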

Compound 4, intrinsic clearance in microsomes in the Homo sapiens assay: < 4 mL.min-1.g-1
Compound 4: a limit, no number; the forecaster's own chance of this, stated with the estimate: 5%; middle value at least 15-fold (1.17 log units) from the limit.
By their numbers in the Homo sapiens assay, from the lowest: compound 1; then compound 3; then compound 2. At a limit, below all of these: compound 4.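

In the Homo sapiens assay compound 4 gives < 4 mL.min-1.g-1, which is a limit of the assay and not a number. In the Homo sapiens assay this position responds far more strongly than the exchanges of whole groups suggested: a ring nitrogen in place of a ring carbon, with the amino group and the six-membered aromatic ring kept, gives an at least 22-fold lower number from compound 3 to compound 4 (1.34 log units; beyond the scatter). In the Homo sapiens assay the 6-aminopyridazin-3-yl group also sits lower than the two other groups at this place, with an at least 120-fold lower number from compound 2 to compound 4 (2.10 log units; beyond the scatter) and an at least 7.5-fold lower number from compound 1 to compound 4 (0.87 log units; beyond the scatter), and all three steps rest on a limit for compound 4, not a number: the limit of < 4 mL.min-1.g-1 in the Homo sapiens assay, at which 1 of the 4 values shown sits. In a physicochemical assay for lipophilicity (a higher number here means a more lipophilic compound, a lower number a more polar compound), compound 3 gives > 3, which is a limit of the assay and not a number. In the physicochemical assay compound 4 gives 2.6. In the physicochemical assay the same change goes with a number at least 0.40 log units lower from compound 3 to compound 4 (beyond the scatter), read against a limit for compound 3: the limit of > 3 in the physicochemical assay, at which 1 of the 2 values shown sits.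

A single pair read in both assays cannot say whether the fall in clearance and the fall in lipophilicity are linked. From the compounds shown here alone, it also stays open whether the extra ring nitrogen carries the step without the amine, as a methyl group or a hydroxyl group in place of the amino group on the same ring would show.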